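Debenzylation on the shared core: second hydroxy analogue

The source may hold more compounds than are shown below. What is called first, only, known or untested is meant among the compounds shown, and "the series" means these compounds.

Compound 1 `CCOC(=O)C1=C(C)OC2OC(COCc3ccccc3)C(OCc3ccccc3)C(OCc3ccccc3)C2[S+]1[O-]` carries three benzyl groups on its core. Going by the values given here, in an assay on CHO cells for displacement of a labelled ligand from Substance-K receptor (Homo sapiens) (on this read-out lower numbers stand for stronger inhibition and higher numbers for weaker inhibition), compound 1 gives 250 nM, the lowest of the three numbers measured so far. Compound 3 `CCOC(=O)C1=C(C)OC2OC(COCc3ccccc3)C(OCc3ccccc3)C(O)C2[S+]1[O-]` gives 790 nM in this assay. Among the compounds with values here, compound 2 `CCOC(=O)C1=C(C)OC2OC(COCc3ccccc3)C(OCc3ccccc3)C(O)C2S1` differs from compound 3 at the sulfur as well; in this assay compound 2 gives 12600 nM, and no single-point step links compound 2 to the others, so its value stands alone. Within the data shown here, the one relevant step is a 3.2-fold higher number from compound 1 to compound 3 (0.50 log units; beyond the scatter), a benzyl replaced by hydrogen on an oxygen on a saturated carbon.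

Compound 4 `CCOC(=O)C1=C(C)OC2OC(COCc3ccccc3)C(O)C(OCc3ccccc3)C2[S+]1[O-]` has not been measured. It differs from compound 1 by hydrogen in place of benzyl on an oxygen on a saturated carbon, the same kind of change at a different oxygen on a saturated carbon whose other neighbours are saturated ring carbons. Because compound 3 showed a 3.2-fold higher number from compound 1 to compound 3 (0.50 log units; beyond the scatter) for the analogous change, a modest rise in this assay of similar size is expected, so that a 2.8-fold higher number from compound 1 to compound 4 (0.45 log units; beyond the scatter) is the estimated step. For compound 4 the expected value in this assay is 700 nM, with a range from 250 nM to 2500 nM.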

Compound 4, inhibition constant: > 10000 nM
Compound 4: no number, only a limit; the forecaster's own chance of this, stated with the estimate: 5%; at least 14-fold (1.15 log units) between middle value and limit.
By their numbers in this assay, from the lowest: compound 1; then compound 3; then compound 2.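

The same change, benzyloxy to hydroxy, does not cost the same at each oxygen: this oxygen gives an at least 40-fold higher number from compound 1 to compound 4 (1.60 log units; beyond the scatter), against a 3.2-fold higher number from compound 1 to compound 3 (0.50 log units; beyond the scatter) at the oxygen changed in compound 3. In this assay compound 4 gives > 10000 nM, which is a limit of the assay and not a number. Going by these compounds alone, the benzyl on this oxygen therefore counts for much more than the one removed in compound 3, although this reading rests on only one pair of compounds at each oxygen.

Still open, going by these compounds, is whether the benzyl itself is needed here, or whether a methyl ether, a longer alkyl chain or a substituted benzyl on this oxygen would hold the value of compound 1. On these data alone, the response of the third benzyl to the same change also remains open.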